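From a bromophenoxy chain to a phenyl chain

The source may report more compounds than this note shows. Statements on the series, on what has been measured and on what is new or still open speak of the compounds shown alone.

Compound 3 `O=C(O)c1cnc2cc(OCCOc3ccc(Br)cc3)ccc2c1O` gives 5130 nM in an assay on isolated protein with malate dehydrogenase, mitochondrial (Sus scrofa) as the target (on this read-out lower numbers stand for stronger inhibition and higher numbers for weaker inhibition), the lowest of the three numbers recorded. Compound 1 `O=C(O)c1cnc2cc(OCc3cccc4ccccc34)ccc2c1O` gives 13200 nM in this assay, and compound 2 `O=C(O)c1ccc2c(O)c(C(=O)O)cnc2c1`, which carries no side chain on the shared core, gives 1070000 nM. Both gaps lie beyond the scatter, so compound 3 stands as the most potent of the three. Compound 4 `O=C(O)c1cnc2cc(OCCc3ccccc3)ccc2c1O` differs from compound 3 in one place: phenyl in place of 4-bromophenoxy on a saturated chain carbon, two bonds along the chain from an oxygen on an aromatic ring. Among the measured compounds shown here, no measured pair shows this change, so its size is uncertain. A moderate loss is expected, because compound 2 with 1070000 nM shows how much the side chain contributes. Compound 4 is therefore expected to give 18000 nM, in a range of 6000 nM to 55000 nM. The expected step of a 3.5-fold higher number from compound 3 to compound 4 (0.55 log units; beyond the scatter) would lie beyond the scatter.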

Compound 4, half-maximal inhibitory concentration: 38000 nM
The estimate for compound 4 lay 2.1-fold (0.32 log units) below the measured number, within the range that was stated.
By their numbers in this assay, from the lowest: compound 3; then compound 1; then compound 4; then compound 2.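

In this assay, replacing 4-bromophenoxy with phenyl on this saturated chain carbon gives a 7.4-fold higher number from compound 3 to compound 4 (0.87 log units; beyond the scatter) and so weakens inhibition, which shows that the group at this place matters to the read-out. The change removes an oxygen and a bromine together, so the step belongs to the two losses jointly. Nothing measured here gives a reason for the step. From the compounds shown here alone, it remains open which loss carries the step: a plain phenoxy group or a 4-bromophenyl group at this place would separate the oxygen from the bromine.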